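This account rests on a few compounds, and the source may have more. Where it says the series, first, only, none or still open, it means among the compounds named here.

Notes on the series. In a functional assay on HepG2 cells (Homo sapiens) for antiproliferative activity, read by CCK-8 assay, with a stated time of 72 h (a lower number here means a stronger inhibitor, a higher number a weaker inhibitor), compound 1 `COc1ccc(C(=O)Nc2cccc(-c3oc4cc(-c5ccc(F)cc5)ccc4c(=O)c3O)c2)cc1` gives 8420 nM. Among the measured compounds shown here, compound 2 `O=C(Nc1cccc(-c2oc3cc(-c4ccc(F)cc4)ccc3c(=O)c2O)c1)c1ccc(C(F)(F)F)cc1` gives 42700 nM in this assay, the highest of the two numbers so far; its only neighbour is compound 1, and the step of a 5.1-fold higher number from compound 1 to compound 2 (0.71 log units; beyond the scatter) went beyond the scatter. Compound 3 `CCCc1ccc(C(=O)Nc2cccc(-c3oc4cc(-c5ccc(F)cc5)ccc4c(=O)c3O)c2)cc1` has not yet been measured in this assay. The change from compound 2 to compound 3 is propyl in place of trifluoromethyl on an aromatic carbon. For the measured compounds named here, only one measured step bears on it: a 5.1-fold higher number from compound 1 to compound 2 (0.71 log units; beyond the scatter) shows that exchanging the group on the aromatic carbon moves the number beyond the scatter, with trifluoromethyl giving the higher number. Propyl is neither of the two groups measured, so the direction rests on little; a step back toward the number of compound 1, smaller than the measured one, is expected. For compound 3 the step of a 2.1-fold lower number from compound 2 to compound 3 (0.33 log units; beyond the scatter) is expected, giving an estimated 20000 nM with a range from 6000 nM to 60000 nM.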

Compound 3, half-maximal inhibitory concentration: 51500 nM
Compound 3: middle estimate off by 2.6-fold (0.41 log units), on the low side; the measured number falls inside the stated range.
By their numbers in this assay, from the lowest: compound 1; then compounds 2 and 3 (each within the scatter of the next).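

In this assay, a 1.2-fold higher number from compound 2 to compound 3 (0.08 log units; within the scatter) lies within the scatter, so trifluoromethyl and propyl on this aromatic carbon, para to a large group, cannot be told apart. By contrast, a 6.1-fold higher number from compound 1 to compound 3 (0.79 log units; beyond the scatter) lies beyond the scatter, so two different replacements of the methoxy of compound 1 now give numbers beyond the scatter on the higher side, and compound 1 stands alone at the lower end of these three compounds. Nothing at hand bears on what lies behind these numbers.

Open, from the compounds shown here alone, is whether the lower number belongs to methoxy alone or whether another oxygen-linked group, such as ethoxy or hydroxyl, would match it. Also open, going by these compounds, is how an amine, a carboxylic acid or a longer chain at this place would read.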